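The source may hold more compounds than are shown below. What is called first, only, known or untested is meant among the compounds shown, and "the series" means these compounds.

Compound 1 `COc1ccc(-n2nc(Sc3ccc(Cl)cc3)cc(CC[C@@H](C)NC(=O)[C@H]3CNCC[C@@H]3c3cccc(Cl)c3)c2=O)cc1`: in an assay on CHO cells for binding affinity to Melanocortin receptor 4 (Homo sapiens) (a lower number here means a stronger inhibitor, a higher number a weaker inhibitor), compound 1 gives 43 nM.
Compound 2 `COc1ccc(-n2nc(Sc3ccc(Cl)cc3)cc(CC[C@@H](C)NC(=O)[C@H]3CCNC[C@@H]3c3ccc(Cl)cc3Cl)c2=O)cc1`: in this assay compound 2 gives 36 nM.
Compound 3 `COc1ccc(-n2nc(Sc3ccc(Cl)cc3)cc(CC[C@@H](C)NC(=O)[C@H]3CNC[C@@H]3c3ccc(F)cc3)c2=O)cc1`: in this assay compound 3 gives 70 nM.

All three measured compounds share the same core and the same side chain; they differ in the saturated ring attached to the amide and in the substituted phenyl ring on that saturated ring. In this assay the three numbers lie close together: the value of compound 3 is the highest of the three, but its gap to compound 1 and its gap to compound 2 both fall within the usual scatter, so none of the three can be called stronger or weaker than the others on this evidence.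

Compound 4 `COc1ccc(-n2nc(Sc3ccc(Cl)cc3)cc(CC[C@@H](C)NC(=O)[C@H]3CNC[C@@H]3c3ccc(C)cc3)c2=O)cc1` keeps everything of compound 3 except one substituent on the phenyl ring: the change is methyl in place of fluoro on an aromatic carbon. For the measured compounds named here, no pair of measured compounds differs in just this way, so there is no measured step to lean on. A swap of one small group for another of the same size, with no donor, acceptor or charge gained or lost, is expected to shift this assay little, if at all; the estimated step from compound 3 to compound 4 is a 1.2-fold lower number from compound 3 to compound 4 (0.07 log units; within the scatter), a change not expected to exceed the scatter. Compound 4 is therefore estimated at 60 nM, with a likely range from 25 nM to 150 nM.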

Compound 4, half-maximal inhibitory concentration: 28 nM
Compound 4: the middle estimate sits 2.1-fold (0.33 log units) above what was measured; the measured number falls inside the stated range.
By their numbers in this assay, from the lowest: compounds 4, 2, 1 and 3 (each within the scatter of the next, the first and the last beyond it).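

In this assay, putting methyl in place of fluoro on the 4-fluorophenyl group gives a 2.5-fold lower number from compound 3 to compound 4 (0.40 log units; beyond the scatter), so this position on the ring responds measurably to the exchange of one heavy atom for another, even though neither group carries a hydrogen-bond donor, a hydrogen-bond acceptor or a charge. The earlier compounds shown here could not show this: they differ from one another in more than one place, and their numbers all lie within the scatter of each other, so they gave no reading of any single change. Why methyl gives the lower number here remains unexplained, as nothing measured on these compounds speaks to the cause.

With only fluoro and methyl shown at this position, it remains open how the number would respond to a larger or different group on the same carbon, such as an ethyl group, a nitrile, an amine or a carboxylic acid. As far as these compounds go, it is also open whether the same exchange would give a similar step on the different saturated rings of compound 1 and compound 2.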